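Compound 3 and a Shorter Side Chain

The source may report more compounds than this note shows. Statements on the series, on what has been measured and on what is new or still open speak of the compounds shown alone.

In an ADME assay on NCM460 cells (Homo sapiens) for cytotoxicity, read by CCK-8 assay, with a stated time of 48 h (a higher number here means a weaker inhibitor, a lower number a stronger inhibitor), compound 1 (`COc1ccc(/C=C\c2cc(OC)c(OC)c(OC)c2)cc1OCc1ccc(CN2CCCC[C@H]2C(=O)O)cc1`) gives > 50000 nM as a limit and not a number. Compound 2 (`COc1ccc(/C=C\c2cc(OC)c(OC)c(OC)c2)cc1OCc1ccc(CN2CCCC[C@@H]2C(=O)O)cc1`) gives > 50000 nM as a limit too. Going by the values given here, compound 3 (`COc1ccc(/C=C\c2cc(OC)c(OC)c(OC)c2)cc1OCc1ccc(CNCCO)cc1`) gives 39000 nM as the only actual number so far. Compound 4 (`COc1ccc(/C=C\c2cc(OC)c(OC)c(OC)c2)cc1OCc1ccc(CO)cc1`) carries hydroxy in place of (2-hydroxyethyl)amino on a saturated chain carbon bound to an aromatic carbon. Two measured steps change the group at this same place (an at least 1.2-fold lower number from compound 1 to compound 3 (0.10 log units; that floor lies within the scatter) and an at least 1.2-fold lower number from compound 2 to compound 3 (0.10 log units; that floor lies within the scatter)) and neither floor goes beyond the scatter. They fix no direction, so the expected step (a 1.1-fold lower number from compound 3 to compound 4 (0.05 log units; within the scatter)) stays within the scatter. Compound 4 is estimated at 35000 nM with 10000 nM to 70000 nM as the expected range.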

Compound 4, half-maximal inhibitory concentration: > 50000 nM
Compound 4 was reported as a limit; the forecaster's own chance of this, stated with the estimate: 30%; middle value at least 1.4-fold (0.15 log units) away from the limit.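

In this assay, putting hydroxy in place of (2-hydroxyethyl)amino on this saturated chain carbon gives an at least 1.2-fold higher number from compound 3 to compound 4 (0.10 log units; that floor lies within the scatter), so even this much smaller group shows no step beyond the scatter. The steps to compound 4 from compound 1 and compound 2 cannot be read, as both ends are limits. Compound 3 therefore remains the only one with an actual number, and the others share one limit: the limit of > 50000 nM in this assay, at which 3 of the 4 values shown sit.

As far as these compounds go, how far compound 4 truly lies from compound 3 remains open. So does whether a dimethylamino group or a longer chain here would give a clearly different number.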